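Methyl on the Ring Amine of Compound 2

The source may report more compounds than this note shows. Statements on the series, on what has been measured and on what is new or still open speak of the compounds shown alone.

Of the compounds shown here, two have been measured in an in vitro functional assay on SH-EP1 cells for agonist activity at Neuronal acetylcholine receptor; alpha4/beta2 (Homo sapiens), read by FLIPR and calcium flux; a higher number here means that more compound is needed for the effect, a lower number that less compound is needed. Compound 1 `C1=C(c2cncnc2)CC2CNCC1C2` gives 240 nM in this assay. Compound 2 `CC(C)Oc1cncc(C2=CC3CNCC(C2)C3)c1` gives 164 nM in this assay. Going by the values given here, the two numbers lie within the usual scatter of each other, so they are best read as the same result, and compound 2 is the one whose number comes out lowest on paper without that meaning anything beyond the scatter.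

Compound 3 `CC(C)Oc1cncc(C2=CC3CC(C2)CN(C)C3)c1` has not yet been measured. It differs from compound 2 in one place: methyl in place of hydrogen on an amine nitrogen in a ring. The bridged two-ring core, the six-membered aromatic ring and the isopropoxy group are unchanged.

Among the compounds with values here, no pair of measured compounds here differs by this kind of change, so there is no measured step to lean on. The expected step from compound 2 to compound 3 in this assay is a 2.4-fold higher number from compound 2 to compound 3 (0.39 log units; beyond the scatter), that is, a modestly higher number, which may or may not exceed the scatter. On that basis compound 3 is estimated at 400 nM in this assay, with a range from 150 nM to 1200 nM.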

Compound 3, half-maximal effective concentration: > 10000 nM
Compound 3: no number, only a limit; the forecaster's own chance of this, stated with the estimate: 10%; middle value at least 25-fold (1.39 log units) from the limit.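

Compounds 1 and 2 both carry hydrogen on the amine nitrogen in the ring, so they gave no sign of how much this position would tolerate, and their two values could not be told apart. In this assay, methyl in place of hydrogen at this position gives an at least 60-fold higher number from compound 2 to compound 3 (1.78 log units; beyond the scatter), so adding a single carbon atom here, with the rest of the molecule unchanged, is enough to move the result from a measurable value to the end of the assay's range. The size of this step is therefore a lower bound and not a measured difference, since compound 3 has no number of its own, only a limit: the limit of > 10000 nM in this assay, at which 1 of the 3 values shown sits.

The compounds shown do not tell whether this nitrogen must carry hydrogen or whether methyl is a special case, and an ethyl group, a longer chain or an acetyl group on the same nitrogen would separate those two readings. They also leave open whether the same methyl would have a similar effect on compound 1, which has a different six-membered aromatic ring and no isopropoxy group.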